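The source may hold more compounds than are shown below. What is called first, only, known or untested is meant among the compounds shown, and "the series" means these compounds.

Measured compounds:
- compound 1, `COc1ccc(/C=C2\CN(C(=S)SCc3cn(Cc4ccccc4Cl)nn3)C/C(=C\c3ccc(OC)cc3)C2=O)cc1`: > 100000 nM
- compound 2, `COc1ccc(/C=C2\CN(Cc3cn(Cc4ccc(F)cc4)nn3)C/C(=C\c3ccc(OC)cc3)C2=O)cc1`: > 100000 nM
- compound 3, `O=C1/C(=C/c2ccccc2F)CN(Cc2cn(Cc3ccccc3F)nn2)C/C1=C\c1ccccc1F`: 6000 nM

In a functional assay on MCF7 cells (Homo sapiens) for cytotoxicity, read by MTT assay, with a stated time of 24 h (on this read-out lower numbers stand for stronger inhibition and higher numbers for weaker inhibition), compound 1 gives only a limit, > 100000 nM, not a number. Compound 2 likewise reaches only a limit in this assay, > 100000 nM. Among the measured compounds shown here, compound 3 is the one member of this set with a measured number, giving 6000 nM in this assay. Two of the three values therefore sit at the limit of > 100000 nM in this assay, at which 2 of the 3 values shown sit, and compound 1 is one of them.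

The unmeasured compound 4, `COc1ccc(/C=C2\CN(C(=S)SCc3cn(Cc4cccc(Cl)c4)nn3)C/C(=C\c3ccc(OC)cc3)C2=O)cc1`, shares its core with compound 1. The two are built from the same atoms joined differently: 3-chlorophenyl in place of 2-chlorophenyl on a saturated chain carbon bound to an aromatic nitrogen.

No step between measured compounds is available, so the size of the change from compound 1 to compound 4 cannot be read from any pair shown. Because compound 1 gives > 100000 nM only as a limit, the step is expected to be none beyond the scatter in this assay, and compound 4 is expected to sit at or near the same limit. The estimate for compound 4 in this assay is 100000 nM, with a range from 20000 nM to 300000 nM; the step of a number no higher from compound 1 to compound 4 (the limit leaves the size open) is thus expected to be essentially flat.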

Compound 4, half-maximal inhibitory concentration: 32000 nM
Compound 4: middle estimate off by 3.1-fold (0.49 log units), on the high side; the measured number falls inside the stated range.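

In this assay, among the compounds shown here, 3-chlorobenzyl in place of 2-chlorobenzyl gives an at least 3.1-fold lower number from compound 1 to compound 4 (0.49 log units; beyond the scatter), the first step in this set that can be read between compounds differing in one place. For the compounds shown here, with the same atoms joined differently, it shows that the read-out at this place responds to where the chlorine stands, which the earlier compounds, differing in several places, could not show. From the compounds shown here alone, the true size of the step stays open, since compound 1 is recorded only as a limit: the limit of > 100000 nM in this assay, at which 2 of the 4 values shown sit.

The compounds shown leave open how 4-chlorobenzyl or an unsubstituted benzyl would behave at this place. They also leave open whether the same change would hold on the core of compound 3, which gives 6000 nM in this assay.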